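Carboxylic acid for morpholine amide on a second core

This account rests on a few compounds, and the source may have more. Where it says the series, first, only, none or still open, it means among the compounds named here.

Compound 1 `CCOc1cc2[nH]c(Cc3nn(CC(=O)N4CCOCC4)c(=O)c4ccccc34)nc2cc1Cl`: 22 nM
Compound 2 `O=C(Cc1nn(CC(=O)N2CCOCC2)c(=O)c2ccccc12)Nc1ccc(OC(F)(F)F)c(Cl)c1`: 103 nM
Compound 3 `CCOc1cc2[nH]c(Cc3nn(CC(=O)O)c(=O)c4ccccc34)nc2cc1Cl`: 109 nM

Of the compounds shown here, three have been measured in a functional assay on CHO cells for antagonist activity at sphingosine 1-phosphate receptor 2 (Homo sapiens), read by GTPgammaS binding; a higher number here means a weaker inhibitor, a lower number a stronger inhibitor. Compound 1 and compound 3 share a core and differ in one place: hydroxy in place of morpholin-4-yl on a carbonyl carbon. That single change produced a 5.0-fold higher number from compound 1 to compound 3 (0.70 log units; beyond the scatter), a step beyond the usual scatter of the measurement, so the acid form is the weaker inhibitor of the two.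

Compound 2 carries a different core from compound 1; the difference between the two cores is not broken down here. In this assay compound 2 and compound 3 give numbers that lie within the scatter of each other, so nothing separates them.

Compound 4 `O=C(O)Cn1nc(CC(=O)Nc2ccc(OC(F)(F)F)c(Cl)c2)c2ccccc2c1=O` has not yet been measured. It stands to compound 2 as compound 3 stands to compound 1: hydroxy in place of morpholin-4-yl on a carbonyl carbon. The surroundings of the change are described in the same words in both cases, a carbonyl carbon whose other neighbour is a saturated chain carbon, so this is the same change carried onto the core of compound 2.

For the measured compounds named here, the expectation is that compound 4 will show a step of about the same size as the earlier one, because a 5.0-fold higher number from compound 1 to compound 3 (0.70 log units; beyond the scatter) is the only guide available; for compound 4 that means an expected 4.9-fold higher number from compound 2 to compound 4 (0.69 log units; beyond the scatter). Since this rests on a single prior instance on a different core, the range is kept wide. Compound 4 is estimated at 500 nM, expected to fall between 150 nM and 1600 nM.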

Compound 4, half-maximal inhibitory concentration: 754 nM
For compound 4 the middle estimate is 1.5-fold (0.18 log units) below the measured one; the range from low to high includes it.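

In this assay, putting hydroxy in place of morpholin-4-yl on the carbonyl carbon of the second core gave a 7.3-fold higher number from compound 2 to compound 4 (0.86 log units; beyond the scatter), so the carboxylic acid is again the weaker inhibitor of its pair, as it was on the first core. The two steps point the same way, and the gap between their sizes is no larger than repeat measurements could produce, so they cannot be told apart: the same change on two cores in this assay, a 5.0-fold higher number (0.70 log units; beyond the scatter) from compound 1 to compound 3 and a 7.3-fold higher number (0.86 log units; beyond the scatter) from compound 2 to compound 4, 1.5-fold (0.17 log units) apart, within the scatter of two such steps This shows that, across these two cores, the change carries over with much the same loss, and that a step read on one core was a fair guide to the other; it does not show why the morpholine amide gives the lower number, nor that the same would hold on a third core, since two pairs are a small basis for any rule.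

Going by these compounds, both pairs compare only morpholin-4-yl with hydroxy, so it remains open whether the whole morpholine ring matters or whether any amide on this carbonyl carbon would do as well. A piperidin-1-yl amide, a dimethylamino amide or a methyl ester in the same place, on either core, would help to separate those possibilities.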